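From Nitro to Amino on a Shared Core

The source may hold more compounds than are shown below. What is called first, only, known or untested is meant among the compounds shown, and "the series" means these compounds.

Within the data shown here, compound 2 `COc1ccc(-c2nc3cc(Cl)c(Cl)cc3[nH]2)c([N+](=O)[O-])c1` gives 80000 nM in an ADME assay on Vero cells (Chlorocebus sabaeus) for cytotoxicity (a higher number here means that more compound is tolerated, a lower number that less compound is tolerated), the higher of the two numbers known, while compound 1 `COc1ccc(-c2nc3cc(Cl)c(Cl)cc3[nH]2)cc1` gives 30000 nM. Among the measured compounds shown here, the only measured step, a 2.7-fold higher number from compound 1 to compound 2 (0.43 log units; beyond the scatter), is the sole guide. Compound 3 `COc1ccc(-c2nc3cc(Cl)c(Cl)cc3[nH]2)c(N)c1` differs from compound 2 by amino in place of nitro on an aromatic carbon. For the measured compounds named here, since the nitro group that entered in the measured step now leaves, a modest fall toward compound 1 is expected, though the incoming amino group has no precedent here and widens the uncertainty. Compound 3 is therefore estimated at 40000 nM, within 15000 nM to 100000 nM, an expected step of a 2.0-fold lower number from compound 2 to compound 3 (0.30 log units; within the scatter).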

Compound 3, half-maximal cytotoxic concentration: 75000 nM
Beside the measured number, compound 3's estimate is 1.9-fold (0.27 log units) below it; measured number inside the range.
By their numbers in this assay, from the lowest: compound 1; then compounds 3 and 2 (each within the scatter of the next).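

In this assay, amino in place of nitro gives a 1.1-fold lower number from compound 2 to compound 3 (0.03 log units; within the scatter), so this assay does not separate the two groups at this position. Measured against hydrogen, amino gives a 2.5-fold higher number from compound 1 to compound 3 (0.40 log units; beyond the scatter), while nitro gives a 2.7-fold higher number from compound 1 to compound 2 (0.43 log units; beyond the scatter), so the higher number seen earlier is not confined to nitro. Nothing measured here explains this shared result.

From the compounds shown here alone, whether a methyl group, a hydroxyl group or a carboxylic acid at this position would also give a higher number than hydrogen remains open.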